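Chain-end amine change: compound 1 to compound 4

The compounds below may be only part of what the source reports. "The series", "measured", "known", "first", "only" and "open" are said of these compounds alone.

All values here come from a functional assay on HT-29 cells (Homo sapiens) for cytotoxicity, read by MTT assay, with a stated time of 72 h; on this read-out higher numbers stand for weaker inhibition and lower numbers for stronger inhibition.

compound 1 `COc1cc2c(Oc3ccc(NC(=O)c4cc(-c5ccccc5)ccn4)cc3F)ccnc2cc1OCCCN1CCN(C)CC1`: 82 nM
compound 2 `COc1cc2c(Oc3ccc(NC(=O)c4cc(-c5ccc(F)cc5)ccn4)cc3F)ccnc2cc1OCCCN1CCN(C)CC1`: 1460 nM
compound 3 `COc1cc2c(Oc3ccc(NC(=O)c4cc(-c5ccccc5F)ccn4)cc3F)ccnc2cc1OCCCN1CCN(C)CC1`: 220 nM

Compound 1 stands lowest of the three numbers in this assay. The nearest is compound 3, with a 2.7-fold higher number from compound 1 to compound 3 (0.43 log units; beyond the scatter); the furthest is compound 2, with an 18-fold higher number from compound 1 to compound 2 (1.25 log units; beyond the scatter). Between those two fluorinated analogues the step is a 6.6-fold lower number from compound 2 to compound 3 (0.82 log units; beyond the scatter), so the position of the fluoro on the phenyl group matters here.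

Compound 4 `COc1cc2c(Oc3ccc(NC(=O)c4cc(-c5ccccc5)ccn4)cc3F)ccnc2cc1OCCCN1CCCC1` is not yet measured. It differs from compound 1 by pyrrolidin-1-yl in place of 4-methylpiperazin-1-yl on a saturated chain carbon, three bonds along the chain from an oxygen on an aromatic ring. None of the three measured steps bears on this change: each of them alters only the phenyl group on the amide side, and the chain end is identical in compound 1, compound 2 and compound 3. Going by the values given here, there is thus no measured step from which to read a direction, and the expectation rests on compound 1 alone, with 82 nM as the anchor.

Compound 4 is therefore expected to give about 120 nM, within 30 nM to 500 nM, which amounts to an expected step of a 1.5-fold higher number from compound 1 to compound 4 (0.17 log units; within the scatter), not clearly beyond the scatter in either direction.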

Compound 4, half-maximal inhibitory concentration: 120 nM
Estimate against measurement, compound 4: no gap at the digits printed, within the range that was stated.
By their numbers in this assay, from the lowest: compounds 1, 4 and 3 (each within the scatter of the next, the first and the last beyond it); then compound 2.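

The chain end now has a measured step: in this assay the change gives a 1.5-fold higher number from compound 1 to compound 4 (0.17 log units; within the scatter) so compound 1 and compound 4 cannot be told apart. For this pair, 3-(pyrrolidin-1-yl)propyl stands in place of 3-(4-methylpiperazin-1-yl)propyl without a step beyond the scatter, whereas both fluoro steps on the phenyl group of compound 1 lie beyond it. Nothing measured here explains this result.

From the compounds shown here alone, whether a morpholin-4-yl or dimethylamino group at the chain end, or a longer chain, would also stay within the scatter of compound 1 remains open. Also open, going by these compounds, is whether the pyrrolidin-1-yl end would give a similar step when combined with the 4-fluorophenyl group of compound 2 or the 2-fluorophenyl group of compound 3.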